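Pyrazine swap on the sulfonamide biaryl series

The compounds below may be only part of what the source reports. "The series", "measured", "known", "first", "only" and "open" are said of these compounds alone.

Three measured analogues share the sulfonamide core: compound 1 `CC(C)(C)c1ccc(S(=O)(=O)Nc2ccc(Cl)cc2-c2c(O)ccc[n+]2[O-])cc1`, compound 2 `CC(C)(C)c1ccc(S(=O)(=O)Nc2ccc(Cl)cc2-c2nc(N)ncc2O)cc1` and compound 3 `CC(C)(C)c1ccc(S(=O)(=O)Nc2ccc(Cl)cc2-c2ncnc(CO)c2O)cc1`. In an assay on isolated protein for antagonist activity at C-C chemokine receptor type 9 (Homo sapiens) (on this read-out higher numbers stand for weaker inhibition and lower numbers for stronger inhibition), compound 1 gives 1750 nM, compound 2 gives 30 nM and compound 3 gives 325 nM. Compound 3 therefore holds the second highest of the three numbers, sitting between compound 1 and compound 2. The measured steps are a 58-fold lower number from compound 1 to compound 2 (1.77 log units; beyond the scatter), a 5.4-fold lower number from compound 1 to compound 3 (0.73 log units; beyond the scatter) and an 11-fold higher number from compound 2 to compound 3 (1.03 log units; beyond the scatter): every exchange of the aryl group on this carbon has moved the number beyond the scatter, with the aminopyrimidine of compound 2 the lowest so far.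

Compound 4 `CNc1nccnc1-c1cc(Cl)ccc1NS(=O)(=O)c1ccc(C(C)(C)C)cc1` is the next step from compound 3. The change is a group of 8 heavy atoms (5 carbon, 3 nitrogen; one six-membered aromatic ring with 2 hetero atoms) in place of a group of 9 heavy atoms (5 carbon, 2 nitrogen, 2 oxygen; one six-membered aromatic ring with 2 hetero atoms), on an aromatic carbon; what enters is a 3-(methylamino)pyrazin-2-yl, and it sits ortho to a large group and meta to a chloro group. For the measured compounds named here, no measured step copies this exchange; the closest guide is an 11-fold higher number from compound 2 to compound 3 (1.03 log units; beyond the scatter), which shows that the substituents on this ring can move the number well beyond the scatter. The direction for compound 4 is open, so a modest step in this assay is expected, a 1.3-fold lower number from compound 3 to compound 4 (0.11 log units; within the scatter), with wide uncertainty. Compound 4 is estimated at 250 nM, within 50 nM to 1200 nM.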

Compound 4, half-maximal inhibitory concentration: 235 nM
For compound 4 the middle estimate is 1.1-fold (0.03 log units) above the measured one; measured number inside the range.
By their numbers in this assay, from the lowest: compound 2; then compounds 4 and 3 (each within the scatter of the next); then compound 1.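

In this assay, putting the 3-(methylamino)pyrazin-2-yl on this aromatic carbon gives a 1.4-fold lower number from compound 3 to compound 4 (0.14 log units; within the scatter), so this group, with 1 hydrogen-bond donor, 3 hydrogen-bond acceptors and no oxygen, stands level with the group of compound 3, which has 2 hydrogen-bond donors and 4 hydrogen-bond acceptors. The other two new steps place the group in the same middle band, with a 7.4-fold lower number from compound 1 to compound 4 (0.87 log units; beyond the scatter) on one side and a 7.8-fold higher number from compound 2 to compound 4 (0.89 log units; beyond the scatter) on the other, so compound 2 stays the most potent of the four and oxygen in the entering group is not required to stay clear of compound 1. No measurement in hand accounts for any of these steps.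

Still open, as far as these compounds go, is what a primary amine or a dimethylamino group would do in place of the methylamino group on the same pyrazine ring, which would show whether that substituent carries any of the effect. Also open, from the compounds shown here alone, is how much of the gap to compound 2 belongs to the ring and how much to its substituents, as the whole group changes in that step.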